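A few compounds are considered here, and "the series" means these few. Any claim that something is new, unique, unknown or untested is made for them only; others in the source may bear on it.

Compound 1 `CC(C)n1ncc2c(C(=O)Nc3cccnc3)cccc21`: in a functional assay on MGC-803 cells (Homo sapiens) for inhibition, read by MTT assay, with a stated time of 72 h (a lower number here means a stronger inhibitor, a higher number a weaker inhibitor), compound 1 reaches only the limit > 40000 nM.
Compound 2 `CC(C)n1ncc2c(C(=O)NCc3cn(-c4cccc(Br)c4)nn3)cccc21`: in this assay compound 2 reaches only the limit > 40000 nM.
Compound 3 `CC(C)n1ncc2c(C(=O)NCc3cn(-c4cccc(F)c4)nn3)cccc21`: in this assay compound 3 reaches only the limit > 40000 nM.

Compound 2 stands at a limit of this assay, not at a number, and no measured value sits beneath it. Among the measured compounds shown here, the single measured step, a step that the two limits leave unreadable from compound 2 to compound 3, cannot be read in size or direction. Compound 4 `CCc1ccc(-n2cc(CNC(=O)c3cccc4c3cnn4C(C)C)nn2)cc1` carries the change (4-ethylphenyl in place of 3-bromophenyl on an aromatic nitrogen). For the measured compounds named here, no measured step bears directly on this change; the only guide is the limit of > 40000 nM in this assay, at which 3 of the 3 values shown sit. The expectation for compound 4 is therefore a value that again stops at the limit, estimated at 40000 nM with a range from 15000 nM to 40000 nM. The step from compound 2 to compound 4 is expected as a number no higher from compound 2 to compound 4 (the limit leaves the size open), with no direction readable beyond the scatter.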

Compound 4, half-maximal inhibitory concentration: > 40000 nM
Compound 4 ended at the assay's limit; the forecaster's own chance of this, stated with the estimate: 80%; the middle value lies on the limit itself.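

Compound 4 gives > 40000 nM in this assay and this is a limit, so the steps to compound 4 from compound 2 and compound 3 cannot be read. The compounds shown leave open which group on the aromatic nitrogen, if any, would give a number instead of a limit.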